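A silyl ether in place of a benzyl ester

This account rests on a few compounds, and the source may have more. Where it says the series, first, only, none or still open, it means among the compounds named here.

Measured compounds:
compound 1, `Nc1cc(C(=O)OCc2ccccc2)ccc1NC(=O)c1ccc(CNc2nccc(-c3cccnc3)n2)cc1`, > 20000 nM
compound 2, `Nc1ccccc1NC(=O)c1ccc(CNC2=NC(=O)C(Cc3c[nH]c4ccccc34)N2)cc1`, > 20000 nM

Compound 1 was tested in an assay on isolated protein for inhibition of protein deacetylase HDAC6 (Homo sapiens), read by fluorescence, with stated times of 3 h and 60 min; on this read-out higher numbers stand for weaker inhibition and lower numbers for stronger inhibition. In this assay compound 1 gives > 20000 nM, which is a limit of the assay and not a number. Compound 2 likewise gives > 20000 nM in this assay, again a limit rather than a number. Compound 1 therefore has no place on a scale of numbers: the limit of > 20000 nM in this assay, at which 2 of the 2 values shown sit. Compound 3, `CC(C)(C)[Si](C)(C)OCc1ccc(NC(=O)c2ccc(CNc3nccc(-c4cccnc4)n3)cc2)c(N)c1`, has not yet been measured. Its change from compound 1 is a group of 9 heavy atoms (7 carbon, 1 oxygen, 1 silicon; no ring) in place of a group of 10 heavy atoms (8 carbon, 2 oxygen; one six-membered aromatic ring of carbon only), on an aromatic carbon. With both known values sitting at the limit, nothing sets a direction, and no step beyond the scatter is expected. The step that the limit leaves unreadable from compound 1 to compound 3 is the one expected here. Compound 3 is expected to give about 25000 nM in this assay, with a range from 8000 nM to 80000 nM, and most likely to be reported once more only as a limit.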

Compound 3, half-maximal inhibitory concentration: > 20000 nM
Compound 3 gave a limit, no number; the forecaster's own chance of this, stated with the estimate: 70%; the middle value lies beyond the limit too.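

Going by these compounds alone, compound 1 and compound 3 are both reported only as limits of the assay and not as numbers, so no step between them can be read. The compounds shown leave open whether any change to these structures would give a measurable value in this assay: the limit of > 20000 nM in this assay, at which 3 of the 3 values shown sit.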